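The source may report more compounds than this note shows. Statements on the series, on what has been measured and on what is new or still open speak of the compounds shown alone.

Measured so far in a physicochemical assay for solubility, read by spectrophotometry, using the shake flask method, with a stated time of 48 h, at pH 6.5; on this read-out higher numbers stand for higher solubility and lower numbers for lower solubility

compound 1 (`O=C(O)COc1ccc2nc(-c3cn(-c4ccc(O)c(F)c4)nn3)ccc2c1`) gives 37 ug/mL
compound 2 (`Oc1ccc(-n2cc(-c3ccc4ccccc4n3)nn2)cc1`) gives 2.2 ug/mL

Going by the values given here, with only two numbers available, compound 1 holds the higher one, and compound 2 lies below it by more than the usual scatter. The next compound to be tested is compound 3 (`NCCOCCOc1ccc2nc(-c3cn(-c4ccc(O)c(F)c4)nn3)ccc2c1`), which keeps the core of compound 1 and differs from it in one place. The change is (2-aminoethoxy)methyl in place of carboxy on a saturated chain carbon bound to an oxygen on an aromatic ring and can be put simply as (2-aminoethoxy)methyl in place of carboxy on a saturated chain carbon bound to an oxygen on an aromatic ring. Cut one bond further out, it reads carboxymethoxy to 2-(2-aminoethoxy)ethoxy.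

Among the compounds with values here, no two measured compounds differ in just one place, so no measured step can guide this forecast, and it remains a judgement starting from compound 1 at 37 ug/mL in this assay as its anchor. A small upward move is expected, possibly no larger than the scatter, and the expected step is a 1.6-fold higher number from compound 1 to compound 3 (0.21 log units; within the scatter) on that judgement. For compound 3 the estimated value is 60 ug/mL with an expected range from 15 ug/mL to 240 ug/mL in this measurement.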

Compound 3, solubility: 9.1 ug/mL
Estimate against measurement, compound 3: 6.6-fold (0.82 log units) above, outside the stated range (below it).
By their numbers in this assay, from the lowest: compound 2; then compound 3; then compound 1.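

Compound 1 and compound 3 are the only pair shown that differ in one place, so the group on the core of compound 1 can now be compared directly with a replacement at the same position. In this assay, putting (2-aminoethoxy)methyl in place of carboxy on a saturated chain carbon bound to an oxygen on an aromatic ring gives a 4.1-fold lower number from compound 1 to compound 3 (0.61 log units; beyond the scatter), a modest step but one beyond the usual scatter, which shows that the read-out does respond to a change at this position and that this replacement lowers the number. No supporting data are available to explain the fall.

This one step swaps the carboxy end for an amine end and also lengthens the chain and adds an ether oxygen, so the compounds shown cannot separate what each of these changes contributes. On these data alone, a 2-(2-hydroxyethoxy)ethoxy chain or a longer chain ending in a carboxylic acid could help pull these changes apart, and whether either would fall nearer compound 1 or compound 3 remains open.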